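Flipping one ring stereocentre in a sphingosine transporter series

The source may hold more compounds than are shown below. What is called first, only, known or untested is meant among the compounds shown, and "the series" means these compounds.

Compound 1 `CCCCCCCCCCc1ccc(-c2noc(CC3CNC3)n2)cc1`: 63%
Compound 2 `CCCCCCCCCCc1ccc(-c2noc([C@H]3CCC[C@@H](N)C3)n2)cc1`: 29%

Among the compounds with values here, in an assay on HeLa cells for inhibition of sphingosine-1-phosphate transporter SPNS2 (Mus musculus), read by LC-MS, tested at 2 uM (on this read-out lower numbers stand for less inhibition and higher numbers for more inhibition at the one concentration tested (going by the name of the read-out)), compound 2 gives 29%, the lowest of the two numbers; its nearest neighbour is compound 1, and the only measured step, a number 34 percentage points lower from compound 1 to compound 2 (beyond the scatter), swaps one amine-bearing group for another. Compound 3 `CCCCCCCCCCc1ccc(-c2noc([C@@H]3CCC[C@@H](N)C3)n2)cc1` differs from compound 2 in this way: the two compounds have the same atoms and bonds and differ only in configuration as drawn: 1 of 2 stereo elements differ; a stereocentre at a saturated ring carbon is drawn S in compound 2 and R in compound 3. Within the data shown here, no measured step mirrors a pure change of configuration, so the data give no direction. A shift of uncertain size is expected, a number 11 percentage points higher from compound 2 to compound 3 (beyond the scatter), and compound 3 is estimated at 40%, ranging from 10% to 75%.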

Compound 3, a percentage reported as inhibition, at one concentration (the size of the read-out at that concentration, not a potency): 13%
For compound 3 the middle estimate is 27 percentage points above the measured one; measured number inside the range.
By their numbers in this assay, from the lowest: compound 3; then compound 2; then compound 1.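

In this assay, the drawn configuration at a single saturated ring carbon matters on its own, with a number 16 percentage points lower from compound 2 to compound 3 (beyond the scatter). This gap can be assigned to that configuration, because nothing else separates the pair: the fact that compounds 2 and 3 differ only in the configuration as drawn. This form of the 3-aminocyclohexyl group also lies further from the (azetidin-3-yl)methyl group, with a number 50 percentage points lower from compound 1 to compound 3 (beyond the scatter).

On these data alone, whether changing the configuration at the other stereocentre, the amine-bearing carbon, would shift the number stays open. So does what a hydroxyl group in place of the amine would do.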